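Swapping a Benzyl for an Amide on the Ring Nitrogen

This account rests on a few compounds, and the source may have more. Where it says the series, first, only, none or still open, it means among the compounds named here.

Compound 1 `Fc1ccc(C(SCCNC2CCN(Cc3ccccc3)CC2)c2ccc(F)cc2)cc1`, compound 2 `Fc1ccc(CN2CCC(NCCSC(c3ccc(F)cc3)c3ccc(F)cc3)CC2)cc1` and compound 3 `OC(Cc1ccccc1)CN1CCC(NCCSC(c2ccc(F)cc2)c2ccc(F)cc2)CC1` share one core and differ only in the group on the ring nitrogen. In an assay on membranes from striatum (strain Sprague-Dawley) for displacement of a labelled ligand from sodium-dependent dopamine transporter (Rattus norvegicus), read by scintillation counting, with a stated time of 120 min (a higher number here means a weaker inhibitor, a lower number a stronger inhibitor), compound 1 gives 32.9 nM, compound 2 gives 25.5 nM and compound 3 gives 31.4 nM. Compound 2 has the lowest of the three numbers, yet each step among them, a 1.3-fold lower number from compound 1 to compound 2 (0.11 log units; within the scatter), a 1.0-fold lower number from compound 1 to compound 3 (0.02 log units; within the scatter) and a 1.2-fold higher number from compound 2 to compound 3 (0.09 log units; within the scatter), stays within the scatter, so the three cannot be told apart. Compound 4 `O=C(c1ccc(F)cc1F)N1CCC(NCCSC(c2ccc(F)cc2)c2ccc(F)cc2)CC1` changes the same place again: (2,4-difluorophenyl)carbonyl in place of 4-fluorobenzyl on an amine nitrogen in a ring. For the measured compounds named here, no measured step puts a carbonyl on that nitrogen, so the earlier steps show tolerance there but do not cover this change, and a modest shift toward a higher number is expected. Compound 4 is expected to give 70 nM, between 25 nM and 250 nM, an estimated 2.7-fold higher number from compound 2 to compound 4 (0.44 log units; beyond the scatter).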

Compound 4, inhibition constant: 30 nM
The estimate for compound 4 lay 2.3-fold (0.37 log units) above the measured number, and the stated range covers the measured number.
By their numbers in this assay, from the lowest: compounds 2, 4, 3 and 1 (each within the scatter of the next).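

For the compounds shown here, a carbonyl on the ring nitrogen is tolerated, which no earlier compound could show: in this assay the steps of a 1.2-fold higher number from compound 2 to compound 4 (0.07 log units; within the scatter) and a 1.0-fold lower number from compound 3 to compound 4 (0.02 log units; within the scatter) and a 1.1-fold lower number from compound 1 to compound 4 (0.04 log units; within the scatter) leave compound 4 indistinguishable from the other three. This position therefore accepts (2,4-difluorophenyl)carbonyl as well as the 4-fluorobenzyl, benzyl and 2-hydroxy-3-phenylpropyl groups. Nothing shown here gives a reason for this tolerance.

Going by these compounds, whether the position would also accept a carboxylic acid or a plain hydrogen on that nitrogen stays open. So does whether a longer chain between the carbonyl and the aromatic ring would fit.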